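Piperazine Variation at the Upper Limit of Agonist Testing

This account rests on a few compounds, and the source may have more. Where it says the series, first, only, none or still open, it means among the compounds named here.

Measured compounds:
Compound 1, `CN(C[C@H]1Cc2c(cccc2N2CCN(C3COC3)CC2)CN1)[C@H]1CCCc2cccnc21`, > 30000 nM
Compound 2, `CN(C[C@H]1Cc2c(cccc2N2CCNCC2)CN1)[C@H]1CCCc2cccnc21`, > 30000 nM
Compound 3, `CC(C)N1CCN(c2cccc3c2C[C@H](CN(C)[C@H]2CCCc4cccnc42)NC3)CC1`, > 30000 nM

Compound 3 carries a 4-isopropylpiperazin-1-yl group on the shared core. In a functional assay on CCRF-CEM cells for agonist activity at C-X-C chemokine receptor type 4 (Homo sapiens), read by calcium flux, with a stated time of 25 min (on this read-out lower numbers stand for an effect already at smaller amounts and higher numbers for an effect only at larger amounts of compound), compound 3 gives > 30000 nM, which is a limit of the assay and not a number. Compound 1 likewise returns a limit in this assay, > 30000 nM. Compound 2 also returns only a limit, > 30000 nM. All three values sit at the limit of > 30000 nM in this assay, at which 3 of the 3 values shown sit, so the steps a step that the two limits leave unreadable from compound 1 to compound 2, a step that the two limits leave unreadable from compound 1 to compound 3 and a step that the two limits leave unreadable from compound 2 to compound 3 cannot be read in size: hydrogen, isopropyl and oxetan-3-yl on the amine nitrogen in the ring all leave the series at the limit.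

Compound 4, `CN(C[C@H]1Cc2c(cccc2N2CCNC(C)(C)C2)CN1)[C@H]1CCCc2cccnc21`, differs from compound 3 by 3,3-dimethylpiperazin-1-yl in place of 4-isopropylpiperazin-1-yl on an aromatic carbon. The change keeps the six-membered non-aromatic ring with its two hetero atoms and moves the substitution within it, adding one hydrogen-bond donor. For the measured compounds named here, no measured step in this assay gives a readable size for any variation of this ring, so nothing points to a gain beyond the scatter. Compound 4 is therefore expected to remain at the limit, with an estimated step that the limit leaves unreadable from compound 3 to compound 4. The estimate for compound 4 in this assay is 40000 nM, within a range from 15000 nM to 150000 nM.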

Compound 4, half-maximal effective concentration: > 30000 nM
Compound 4 gave a limit, no number (the forecaster's own chance of this, stated with the estimate: 85%); the middle value does not contradict the limit.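

In this assay compound 4 gives > 30000 nM as a limit and not a number. Its steps from compound 1, compound 2 and compound 3 therefore cannot be read in size: the limit of > 30000 nM in this assay, at which 4 of the 4 values shown sit. The compounds shown leave open whether any variation of this ring on the shared core gives a readable value.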